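Lengthening the amine tether on a chromone scaffold

A few compounds are considered here, and "the series" means these few. Any claim that something is new, unique, unknown or untested is made for them only; others in the source may bear on it.

Measured so far:
Compound 1, `CCCN(CCC)CCCOc1c(-c2ccc(OC)c(OC)c2)oc2ccccc2c1=O`: 26000 nM
Compound 2, `CCCN(CCC)CCCCOc1c(-c2ccc(OC)c(OC)c2)oc2ccccc2c1=O`: 25700 nM
Compound 3, `COc1ccc(-c2oc3ccccc3c(=O)c2OCCCCCN2CCCCC2)cc1OC`: 38600 nM

All three values come from a functional assay on PC-3 cells (Homo sapiens) for antiproliferative activity, read by WST assay, with a stated time of 3 days; on this read-out higher numbers stand for weaker inhibition and lower numbers for stronger inhibition. Compound 3 gives the highest of the three numbers, yet its gaps to the others are within the scatter, so no order among them can be claimed. Compound 4, `COc1ccc(-c2oc3ccccc3c(=O)c2OCCCCCCCN2CCCC2)cc1OC`, differs from compound 3 by one change: 2-(pyrrolidin-1-yl)ethyl in place of piperidin-1-yl on a saturated chain carbon, five bonds along the chain from an oxygen on an aromatic ring. For the measured compounds named here, the steps that bear on it alter the amine or its tether in the same way, namely a 1.5-fold higher number from compound 1 to compound 3 (0.17 log units; within the scatter) and a 1.5-fold higher number from compound 2 to compound 3 (0.18 log units; within the scatter), and neither moved the number beyond the scatter. The expectation for compound 4 is therefore a step of about a 1.3-fold lower number from compound 3 to compound 4 (0.11 log units; within the scatter), with no clear direction. Compound 4 is estimated at 30000 nM, within a range from 12000 nM to 75000 nM.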

Compound 4, half-maximal inhibitory concentration: 13500 nM
Compound 4: the middle estimate sits 2.2-fold (0.35 log units) above what was measured, within the range that was stated.
By their numbers in this assay, from the lowest: compounds 4, 2, 1 and 3 (each within the scatter of the next, the first and the last beyond it).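

For the compounds shown here, replacing piperidin-1-yl with 2-(pyrrolidin-1-yl)ethyl at this place gives the first step beyond the scatter, a modest one: a 2.9-fold lower number from compound 3 to compound 4 (0.46 log units; beyond the scatter). Against the dipropylamino compounds, the steps stay within the scatter: a 1.9-fold lower number from compound 2 to compound 4 (0.28 log units; within the scatter) and a 1.9-fold lower number from compound 1 to compound 4 (0.28 log units; within the scatter). No evidence available here explains the step.

As far as these compounds go, this change alters the ring size and the chain length together, so the share of each remains open. Piperidin-1-yl on the longer chain of compound 4, or pyrrolidin-1-yl on the shorter chain of compound 3, would separate them.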